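The compounds below may be only part of what the source reports. "The series", "measured", "known", "first", "only" and "open" are said of these compounds alone.

Of the compounds shown here, two have been measured so far. Compound 1 `Cc1cc(O)cc(-c2nn(CC#N)cc2-c2ccnc(-c3ccc(Oc4ccccc4)cc3)c2)c1` and compound 2 `COc1cc(C)cc(-c2nn(CC#N)cc2-c2ccnc(-c3ccc(N(C)C)cc3)c2)c1` share a core but differ in two places at once. In a functional assay on HOP-92 cells (Homo sapiens) for cytotoxicity, read by sulforhodamine B assay, with a stated time of 48 h, tested at 100 nM (a higher number here means a weaker effect of the compound at the concentration tested, a lower number a stronger effect), compound 1 gives 70%, while compound 2 gives 35%, the lower of the two numbers and a gap beyond the usual scatter. Compound 3 `Cc1cc(O)cc(-c2nn(CC#N)cc2-c2ccnc(-c3ccc(N(C)C)cc3)c2)c1` is still to be measured; it changes compound 2 in one place only: hydrogen in place of methyl on an oxygen on an aromatic ring. For the measured compounds named here, no measured pair isolates this change, so only a small step is expected in this assay, likely within the scatter. The expected step is a number 10 percentage points higher from compound 2 to compound 3 (within the scatter). Compound 3 is estimated at 45%, between 20% and 75%.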

Compound 3, a percentage reported as activity, at one concentration (the size of the read-out at that concentration, not a potency): 73%
Estimate against measurement, compound 3: 28 percentage points below, and the stated range covers the measured number.
By their numbers in this assay, from the lowest: compound 2; then compounds 1 and 3 (each within the scatter of the next).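

In this assay, for the compounds shown here, hydroxy in place of methoxy gives a number 38 percentage points higher from compound 2 to compound 3 (beyond the scatter) and so shows, for the first time with only this position changed, that removing one methyl from this oxygen can weaken the read-out substantially. With hydroxy held constant, the change at the other end gives a number 3 percentage points higher from compound 1 to compound 3 (within the scatter) and so shows no distinguishable difference between phenoxy and dimethylamino. No available evidence accounts for the methoxy-to-hydroxy step.
From the compounds shown here alone, it remains open whether ethoxy or an amine at this position would behave more like methoxy or hydroxy. Going by these compounds, it is also open whether the same step would appear with phenoxy at the other end.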